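This account rests on a few compounds, and the source may have more. Where it says the series, first, only, none or still open, it means among the compounds named here.

In a functional assay (Homo sapiens) for antiproliferative activity (a higher number here means a weaker inhibitor of growth, a lower number a stronger inhibitor of growth), compound 1 `Cc1cn2c(/C=N/NC(=N)N)c(-c3ccncc3)nc2s1` gives 39800 nM, compound 2 `Cc1cn2c(/C=N/NC(=N)N)c(-c3cccnc3)nc2s1` gives 25700 nM and compound 3 `Cc1sc2nc(-c3ccccn3)c(/C=N/NC(=N)N)n2c1C` gives 33100 nM. Compound 2 therefore stands within the scatter of both others. The next compound is compound 4 `N=C(N)N/N=C/c1c(-c2cccnc2)nc2sc(Cl)cn12`, with chloro in place of methyl on an aromatic carbon. Among the measured compounds shown here, no measured step covers this change. The only one available, a 1.5-fold lower number from compound 1 to compound 2 (0.19 log units; within the scatter), concerns pyridin-3-yl in place of pyridin-4-yl and stays within the scatter. With no direct methyl-to-chloro comparison in this assay, no step beyond the scatter is expected. The expected change is a 1.3-fold lower number from compound 2 to compound 4 (0.11 log units; within the scatter). Compound 4 is estimated at 20000 nM, with an expected range of 7000 nM to 50000 nM.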

Compound 4, concentration for total growth inhibition: 36300 nM
Beside the measured number, compound 4's estimate is 1.8-fold (0.26 log units) below it; measured number inside the range.
By their numbers in this assay, from the lowest: compounds 2, 3, 4 and 1 (each within the scatter of the next).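

Among the compounds shown here, this is the first reading of a single change on the aromatic carbon next to the ring sulfur: in this assay, chloro in place of methyl gives a 1.4-fold higher number from compound 2 to compound 4 (0.15 log units; within the scatter) and so does not separate the two groups at this position. With pyridin-3-yl held fixed, this position tolerates either group without a change beyond the scatter. Nothing available bears on the reason for this result. Open, on these data alone, is whether an amine, a carboxylic acid or a longer chain at this position would move the number beyond the scatter. Also open, as far as these compounds go, is whether chloro behaves the same way alongside pyridin-4-yl.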